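Swapping a chain group for phenethyl on an aziridinylquinone

This account rests on a few compounds, and the source may have more. Where it says the series, first, only, none or still open, it means among the compounds named here.

Measured compounds in a functional assay on L1210 cells (Mus musculus), with a stated time of 12 days; on this read-out higher numbers stand for higher potency (the scale is a negative logarithm) and lower numbers for lower potency:
- Compound 1 `CC1=C(N2CC2)C(=O)C(CC(C)OC(N)=O)=C(N2CC2)C1=O` gives 6.14
- Compound 2 `O=C1C(CCO)=C(N2CC2)C(=O)C(CCO)=C1N1CC1` gives 6.54
- Compound 3 `CCC1=C(N2CC2)C(=O)C(C(COC(N)=O)OC)=C(N2CC2)C1=O` gives 6.16

Among these three, compound 1 has the lowest number. Its gap to compound 3 is within the usual scatter, so the two cannot be told apart. Compound 2 stands beyond the scatter above compound 1, and so is the only one of the three that is clearly more potent than compound 1.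

The unmeasured compound 4 `CC1=C(N2CC2)C(=O)C(CCCc2ccccc2)=C(N2CC2)C1=O` arises from compound 1 by one change: a group of 8 heavy atoms (8 carbon; one six-membered aromatic ring of carbon only) in place of a group of 6 heavy atoms (3 carbon, 1 nitrogen, 2 oxygen; no ring), on a saturated chain carbon bound to a double-bonded ring carbon. Within the data shown here, no pair of measured compounds differs in a single place, so no measured step tells how large an effect such a swap has. The two neighbours, compound 2 and compound 3, both carry oxygen-bearing chains and sit near or slightly above compound 1, which leaves the direction of this step open. The step from compound 1 to compound 4 is expected to be small, a number 0.14 log units lower from compound 1 to compound 4 (within the scatter), no more than the scatter. Compound 4 is therefore estimated at 6 in this assay, in a range from 5.4 to 6.6.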

Compound 4, logarithm of the reciprocal of the active concentration, log(1/C): 4.47
For compound 4 the middle estimate is 1.53 log units above the measured one; the measured number lies below the stated range.
By their numbers in this assay, from the lowest: compound 4; then compounds 1 and 3 (each within the scatter of the next); then compound 2.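

Among these compounds, this step is the first single change that can be read, and it shows that this position does not accept every group equally: on a saturated chain carbon bound to a double-bonded ring carbon, phenethyl in this assay gives a number 1.67 log units lower from compound 1 to compound 4 (beyond the scatter) and this is a large loss of potency. The chain that leaves carries 1 hydrogen-bond donor and 2 hydrogen-bond acceptors, whereas phenethyl carries neither and brings a six-membered aromatic ring, so several features change in one step. No measurement here gives a reason for the drop.

On these data alone, whether the loss follows the arrival of the ring or the departure of the donor and acceptors stays open. A plain butyl chain without a ring, or an amine or a carboxylic acid at the chain end on the same core, would help to separate the two.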